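This account rests on a few compounds, and the source may have more. Where it says the series, first, only, none or still open, it means among the compounds named here.

Compound 2, whose structure is `C/C(=N\NC(=O)c1cccc(S(=O)(=O)N2CCOCC2)c1)c1cc(O)ccc1O`, carries a 2,5-dihydroxyphenyl on the carbon with a double bond to nitrogen. Among the measured compounds shown here, in a functional assay on EC9706 cells (Homo sapiens) for antiproliferative activity, read by MTT assay, with a stated time of 72 h (a lower number here means a stronger inhibitor, a higher number a weaker inhibitor), compound 2 gives 3510 nM, the only outright number among the values shown here. Its partner compound 1, with structure `C/C(=N\NC(=O)c1cccc(S(=O)(=O)N2CCOCC2)c1)c1cccc(N)c1`, differs only in having a 3-aminophenyl at that position. In this assay compound 1 reaches only a limit, > 100000 nM, and the limit of > 100000 nM in this assay, at which 1 of the 2 values shown sits, marks that limit. For the measured compounds named here, the step of an at least 28-fold lower number from compound 1 to compound 2 (1.45 log units; beyond the scatter) is therefore the single measured step, and it is large.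

Compound 3, with structure `C/C(=N\NC(=O)c1cccc(S(=O)(=O)N2CCOCC2)c1)c1cccc(N)c1O`, is not yet measured. It differs from compound 2 by 3-amino-2-hydroxyphenyl in place of 2,5-dihydroxyphenyl on a carbon with a double bond to nitrogen. The new group shares an amino with the 3-aminophenyl of compound 1 and a hydroxy with the ring of compound 2, so it sits between the two measured cases. Because compound 1 with its 3-aminophenyl reached only the limit > 100000 nM, a weakening in this assay is expected for compound 3, and the estimated step of an 8.5-fold higher number from compound 2 to compound 3 (0.93 log units; beyond the scatter) is in the direction of a higher number. The value expected for compound 3 is 30000 nM, within 5000 nM to 150000 nM.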

Compound 3, half-maximal inhibitory concentration: 3520 nM
The estimate for compound 3 lay 8.5-fold (0.93 log units) above the measured number; measured number below the stated range.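

In this assay, the step of a 1.0-fold higher number from compound 2 to compound 3 (0.00 log units; within the scatter) shows that, on this carbon with a double bond to nitrogen, the 3-amino-2-hydroxyphenyl and the 2,5-dihydroxyphenyl cannot be told apart, so an amino on the ring does not by itself go with the loss seen for compound 1. The step of an at least 28-fold lower number from compound 1 to compound 3 (1.45 log units; beyond the scatter) isolates what the earlier pair could not, since that pair differed in more than one ring substituent: here a single change, hydroxy in place of hydrogen on an aromatic carbon, separates a compound at the limit from one with a measured value. The true size of that step stays unknown, as compound 1 gives a limit and not a number: the limit of > 100000 nM in this assay, at which 1 of the 3 values shown sits.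

The compounds shown leave open whether the hydroxy of compound 3 must remain a free hydroxy, which a methoxy or a fluorine in its place would test, and whether a phenyl carrying that hydroxy alone, with no amino, would match compound 2 and compound 3. They also leave open how a carboxylic acid in place of the amino would fare on the same core.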